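A few compounds are considered here, and "the series" means these few. Any claim that something is new, unique, unknown or untested is made for them only; others in the source may bear on it.

Among the compounds with values here, in a functional assay on HUVEC cells (Homo sapiens), read by BrdU incorporation, with a stated time of 72 h (on this read-out lower numbers stand for stronger inhibition and higher numbers for weaker inhibition), compound 1 `Cc1ccc2nc(Cl)c(/C=C/C(=O)c3ccc(Cl)s3)cc2c1` gives 59.4 nM and compound 2 `Cc1ccc2cc(/C=C/C(=O)c3ccc(Cl)s3)c(Cl)nc2c1` gives 49.5 nM and these two values lie within the usual scatter of each other, so compound 1 stands level with the only other measured compound. The change to compound 3 `Cc1ccc2nc(Cl)c(/C=C/C(=O)c3sccc3Br)cc2c1` is 3-bromothiophen-2-yl in place of 5-chlorothiophen-2-yl on a carbonyl carbon, counted as 3-bromothiophen-2-yl in place of 5-chlorothiophen-2-yl on a carbonyl carbon with the shared core untouched. Within the data shown here, no measured pair shows such a swap, so only a modest move toward weaker inhibition in this assay is expected, an estimated 2.0-fold higher number from compound 1 to compound 3 (0.31 log units; beyond the scatter) with wide uncertainty. The estimate for compound 3 is 120 nM with an expected range of 35 nM to 400 nM.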

Compound 3, half-maximal inhibitory concentration: 61.9 nM
The estimate for compound 3 lay 1.9-fold (0.29 log units) above the measured number, and the stated range covers the measured number.
By their numbers in this assay, from the lowest: compounds 2, 1 and 3 (each within the scatter of the next).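

Placing 3-bromothiophen-2-yl where 5-chlorothiophen-2-yl stood on the carbonyl carbon gives a 1.0-fold higher number from compound 1 to compound 3 (0.02 log units; within the scatter) in this assay. This position therefore accepts a different halogen, at a different place on the ring, with no shift beyond the scatter. Nothing measured here explains why the two groups read alike.

As far as these compounds go, whether the halogen matters at all remains open, as a plain thiophen-2-yl would be needed to tell. So does the response to quite different groups on this carbonyl carbon, such as an amine or a carboxylic acid.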